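Changing the aryl group on the shared core: compound 3

This account rests on a few compounds, and the source may have more. Where it says the series, first, only, none or still open, it means among the compounds named here.

Measured compounds:
- compound 1 `COc1cc(N2C(N)=C(C#N)C(/C=C/c3ccccc3)C3=C2CC(C)(C)CC3=O)cc(OC)c1OC`: 10%
- compound 2 `COc1ccccc1C1C(C#N)=C(N)N(c2cc(OC)c(OC)c(OC)c2)C2=C1C(=O)CC(C)(C)C2`: 30%

Both compounds were tested in a functional assay on Ehrlich cells (Mus musculus) for cytotoxicity, tested at 10 ug/mL; on this read-out lower numbers stand for a weaker effect and higher numbers for a stronger effect at the one concentration tested. Compound 2 stands highest of the two numbers, and its nearest neighbour is compound 1, which lies a number 20 percentage points higher from compound 1 to compound 2 (beyond the scatter) apart, a step beyond the scatter. That step concerns the same saturated ring carbon that is altered here: a 2-methoxyphenyl in place of a 2-phenylethenyl raised the read-out.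

Compound 3 `COc1cc(N2C(N)=C(C#N)C(c3ccc(C)cc3)C3=C2CC(C)(C)CC3=O)cc(OC)c1OC` carries a further change at that position: 4-methylphenyl in place of 2-methoxyphenyl on a saturated ring carbon. Among the measured compounds shown here, no measured step shows this exact swap, so the only guide is that the one change seen at this carbon moved the number modestly. With a 4-methylphenyl replacing the 2-methoxyphenyl, the read-out is expected to stay near that of compound 2, with no step beyond the scatter in either direction, that is, an estimated step of a number 5 percentage points lower from compound 2 to compound 3 (within the scatter).

Compound 3 is therefore estimated to give 25% in this assay, within a range from 5% to 45%.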

Compound 3, a percentage reported as activity, at one concentration (the size of the read-out at that concentration, not a potency): 30%
Compound 3: the middle estimate sits 5 percentage points below what was measured; low and high end bracket the measured number.
By their numbers in this assay, from the lowest: compound 1; then compounds 2 and 3 (each within the scatter of the next).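

In this assay, the swap to 4-methylphenyl on the saturated ring carbon gives no change at the digits printed from compound 2 to compound 3 (within the scatter) even though the 2-methoxyphenyl group has one hydrogen-bond acceptor and the 4-methylphenyl group has none. In this pair, then, losing that acceptor and moving from a methoxy to a methyl substituent leave the read-out within the usual scatter. Compared with the 2-phenylethenyl group, 4-methylphenyl gives a number 20 percentage points higher from compound 1 to compound 3 (beyond the scatter) and so matches the rise already seen with 2-methoxyphenyl, which shows that this rise is not unique to one aryl group.

Still open, as far as these compounds go, is how a plain phenyl group, or an aryl group carrying an amine or a carboxylic acid, would read at this carbon, and whether methyl and methoxy would behave alike if each stood at the other's ring position. No measurement shown gives a reason for any of these read-outs, and with only one tested concentration they say nothing about potency.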